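The compounds below may be only part of what the source reports. "The series", "measured", "known", "first", "only" and "open" are said of these compounds alone.

Working notes on the series. Two members are measured: compound 1 `C=CCn1c(=O)/c(=C\c2cccc(Cl)c2)[nH]c(=O)/c1=C\c1ccccc1OC` and compound 2 `COc1ccccc1/C=c1/[nH]c(=O)/c(=C\c2ccccc2OC)n(C)c1=O` share one core. In a functional assay on U-937 cells (Homo sapiens) for cytotoxicity, read by CCK-8 assay, with a stated time of 72 h (on this read-out lower numbers stand for stronger inhibition and higher numbers for weaker inhibition), compound 1 gives 1200 nM. In this assay compound 2 gives 1500 nM. Compound 2 and compound 1 lie within the usual scatter of each other, so neither ranks ahead of the other on what is known. Among the compounds with values here, no two measured compounds differ in a single place, so no measured step is available to calibrate a change. Compound 3 `COc1ccccc1/C=c1\c(=O)[nH]/c(=C/c2cccc(Cl)c2Cl)c(=O)n1C` is not yet measured. It differs from compound 2 by 2,3-dichlorophenyl in place of 2-methoxyphenyl on a double-bonded chain carbon bound to an aromatic carbon. Compound 1, which also carries a chlorine substituent on a phenyl ring, sits close to compound 2 in this assay, so nothing on hand argues for a move beyond the scatter; the expected step from compound 2 to compound 3 is a 1.3-fold lower number from compound 2 to compound 3 (0.10 log units; within the scatter). For compound 3 the estimate in this assay is 1200 nM, with a range from 450 nM to 3200 nM.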

Compound 3, half-maximal inhibitory concentration: 100 nM
Compound 3: the middle estimate sits 12-fold (1.08 log units) above what was measured; the whole stated range lies above it.
By their numbers in this assay, from the lowest: compound 3; then compounds 1 and 2 (each within the scatter of the next).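

Within the data shown here, the substituted phenyl on a double-bonded chain carbon bound to an aromatic carbon is not a neutral site: in this assay, 2,3-dichlorophenyl in place of 2-methoxyphenyl gives a 15-fold lower number from compound 2 to compound 3 (1.18 log units; beyond the scatter), the first calibrated step. The two groups match in heavy-atom count and in their six-membered aromatic carbon ring, so the change lies in exchanging a group with a hydrogen-bond acceptor for one with two chlorines and none, and this exchange alone is enough for a large step. Nothing on hand bears on the reason for a step of this size.

As far as these compounds go, whether both chlorines are needed remains open, as a phenyl with a single chlorine, an unsubstituted phenyl or a pyridine ring at this place would have to settle it. Also open, from the compounds shown here alone, is whether the same exchange would carry over to the other double-bonded chain carbon, or to a core with a longer chain on the ring nitrogen.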